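The source may report more compounds than this note shows. Statements on the series, on what has been measured and on what is new or still open speak of the compounds shown alone.

Measured in a physicochemical assay for lipophilicity; a higher number here means a more lipophilic compound, a lower number a more polar compound:
- Compound 1 `COC(=O)/C=C(C)/C=C/CC(C)CCCC(C)(C)OC`: 5
- Compound 2 `C=CC(C)OC(=O)/C=C(C)/C=C/CC(C)CCCC(C)(C)OC`: 5.94
- Compound 3 `COC(C)(C)CCCC(C)C/C=C/C(C)=C/C(=O)CC(C)C`: 6.02

Compound 3 shares the upper end of these numbers with one other compound. That gap is small, a number 0.08 log units higher from compound 2 to compound 3 (within the scatter), while the other gap is large, a number 1.02 log units higher from compound 1 to compound 3 (beyond the scatter).

Compound 4 `CCC(C)C(=O)/C=C(C)/C=C/CC(C)CCCC(C)(C)OC` has the same atoms joined differently, with sec-butyl in place of isobutyl on a carbonyl carbon. Among the compounds with values here, no measured step makes this exact swap. The clear steps, a number 0.94 log units higher from compound 1 to compound 2 (beyond the scatter) and a number 1.02 log units higher from compound 1 to compound 3 (beyond the scatter), both replace a smaller group with a larger one, which does not happen here. The closest guide is a number 0.08 log units higher from compound 2 to compound 3 (within the scatter), a change on that same carbonyl carbon. No shift beyond the scatter is therefore expected, and the expected step is a number 0.07 log units lower from compound 3 to compound 4 (within the scatter). For compound 4 the estimated value is 5.95, with an expected range of 5.6 to 6.3.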

Compound 4, partition coefficient: 6.02
The estimate for compound 4 lay 0.07 log units below the measured number; measured number inside the range.
By their numbers in this assay, from the lowest: compound 1; then compounds 2, 3 and 4 (each within the scatter of the next).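

On a carbonyl carbon, sec-butyl and isobutyl are indistinguishable in this assay (no change at the digits printed from compound 3 to compound 4 (within the scatter)), so rearranging these four carbons shows no effect here. Compound 4 also matches compound 2 (a number 0.08 log units higher from compound 2 to compound 4 (within the scatter)), and the large gain over the methoxy compound remains with sec-butyl (a number 1.02 log units higher from compound 1 to compound 4 (beyond the scatter)). Nothing available explains these results.

As far as these compounds go, only branched butyl isomers have been compared at this position, so a straight butyl chain remains open. So does the effect of an amine or a carboxylic acid on that carbonyl carbon.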